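The source may report more compounds than this note shows. Statements on the series, on what has been measured and on what is new or still open speak of the compounds shown alone.

Among the measured compounds shown here, in a functional assay on HL-60 cells (Homo sapiens) for antiproliferative activity (a lower number here means a stronger inhibitor of growth, a higher number a weaker inhibitor of growth), compound 1 `COCCCCCCCCCCC/C=C1\CC(CO)(COC(=O)C(C)(C)C)OC1=O` gives 5.22 ug/mL, the only exact number so far. Compound 2 `CC(C)(C)C(=O)OCC1(CO)C/C(=C\CCCCCCCCCCCO)C(=O)O1` gives > 10 ug/mL, which is a limit of the assay. Compound 3 `CC(C)(C)C(=O)OCC1(CO)C/C(=C\CCCCCCCCCCCCCCC=O)C(=O)O1` gives > 10 ug/mL, also a limit. Compound 4 `CC(=O)NCCCCCCCCCCCCCCC/C=C1\CC(CO)(COC(=O)C(C)(C)C)OC1=O` carries 4-acetamidobutyl in place of the methoxy of compound 1 (4-acetamidobutyl in place of methoxy on a saturated chain carbon, ten or more bonds along the chain from a double-bonded chain carbon). Two measured steps also alter that methoxy: an at least 1.9-fold higher number from compound 1 to compound 2 (0.28 log units; that floor lies within the scatter), and an at least 1.9-fold higher number from compound 1 to compound 3 (0.28 log units; that floor lies within the scatter). Both point towards a higher number, though each floor lies within the scatter. In this assay, a modest step towards weaker growth inhibition is therefore expected: a 1.7-fold higher number from compound 1 to compound 4 (0.24 log units; within the scatter). Compound 4 is expected at about 9 ug/mL, with an estimated range of 4 ug/mL to 20 ug/mL.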

Compound 4, concentration for 50% growth inhibition: > 10 ug/mL
Compound 4: no number, only a limit; the forecaster's own chance of this, stated with the estimate: 55%; middle value at least 1.1-fold (0.04 log units) away from the limit.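

In this assay, 4-acetamidobutyl in place of methoxy gives an at least 1.9-fold higher number from compound 1 to compound 4 (0.28 log units; that floor lies within the scatter). Among the compounds shown here, this third replacement at the same saturated chain carbon again yields only a limit of the assay, not a number, so compound 1 still holds the only exact value: the limit of > 10 ug/mL in this assay, at which 3 of the 4 values shown sit. The steps from compound 2 to compound 4 and from compound 3 to compound 4 cannot be read.

Each floor from compound 1 lies within the scatter, so a real loss of growth inhibition remains unconfirmed. As far as these compounds go, how an amine or a carboxylic acid in place of the methoxy would read stays open.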